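Aminobenzylidene thiazolidinediones: trimming the ring-nitrogen substituent

The source may report more compounds than this note shows. Statements on the series, on what has been measured and on what is new or still open speak of the compounds shown alone.

Among the measured compounds shown here, compound 1 `Nc1ccc(/C=C2\SC(=O)N(Cc3ccc(F)cc3)C2=O)cc1` stands highest of the two values so far in a functional assay on FM3A cells (Mus musculus) for cytotoxicity, read by cell counting, with a stated time of 2 days (a higher number here means a weaker inhibitor, a lower number a stronger inhibitor), giving 36000 nM. Compound 2 `C=C(Br)C(=O)Nc1ccc(/C=C2\SC(=O)N(Cc3ccc(F)cc3)C2=O)cc1` gives 4600 nM; the step of a 7.8-fold lower number from compound 1 to compound 2 (0.89 log units; beyond the scatter) concerns the aromatic amine only. Compound 3 `CCN1C(=O)S/C(=C\c2ccc(N)cc2)C1=O` differs from compound 1 elsewhere: methyl in place of 4-fluorophenyl on a saturated chain carbon bound to an amide-type nitrogen in a ring. No measured step touches the saturated chain carbon bound to the amide-type nitrogen in the ring, so the shown data give no direction for this change. With nothing pointing either way, a step no larger than the scatter is expected, a 1.4-fold higher number from compound 1 to compound 3 (0.14 log units; within the scatter), allowing a wide range. Compound 3 is therefore estimated at 50000 nM in this assay, between 15000 nM and 200000 nM.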

Compound 3, half-maximal inhibitory concentration: 76000 nM
Beside the measured number, compound 3's estimate is 1.5-fold (0.18 log units) below it; low and high end bracket the measured number.
By their numbers in this assay, from the lowest: compound 2; then compound 1; then compound 3.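

With 4-fluorophenyl replaced by methyl on the saturated chain carbon bound to the amide-type nitrogen in the ring, this assay shows a 2.1-fold higher number from compound 1 to compound 3 (0.32 log units; beyond the scatter). This gives the position its first measured direction, and the step is modest, so a number in the same assay remains without the aromatic ring. Nothing shown accounts for this step. Still open, as far as these compounds go, is whether the ring or the fluorine matters, which an unsubstituted phenyl or a longer chain such as propyl at this place would address. Also open, from the compounds shown here alone, is whether the (1-bromoethenyl)carbonyl step seen on the aromatic amine carries over to the methyl compound.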